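Methyl versus chloro on the aryl ring of a shared core

The compounds below may be only part of what the source reports. "The series", "measured", "known", "first", "only" and "open" are said of these compounds alone.

Values in a functional assay on the whole organism for inhibition, with Rattus norvegicus as the target, at a dose of 30 mg/kg; on this read-out lower numbers stand for less inhibition and higher numbers for more inhibition at the one dose given (going by the name of the read-out):
compound 1, `Cc1ccc(-c2nc3cccnc3o2)cc1`: 0%
compound 2, `Clc1ccc(-c2nc3cccnc3o2)cc1`: 14%
compound 3, `Cc1cccc(-c2nc3cccnc3o2)c1`: 14%

Compound 1 and compound 2 share a core and differ only by chloro in place of methyl on an aromatic carbon. That change gives a number 14 percentage points higher from compound 1 to compound 2 (beyond the scatter) in this assay. Compound 3 has the same atoms as compound 1, joined differently; the difference between the two cores is not broken down here. In this assay compound 3 gives 14%, level with compound 2 at the digits printed, and a number above compound 1 that lies beyond the scatter.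

Compound 4, `Clc1cccc(-c2nc3cccnc3o2)c1`, is not yet measured. It differs from compound 3 by chloro in place of methyl on an aromatic carbon. Among the measured compounds shown here, this is the same kind of change as the one from compound 1 to compound 2, not the same: in the first pair the place is para to a group of 9 heavy atoms, in the second pair it is meta to a group of 9 heavy atoms. For the measured compounds named here, only the one measured instance of the change exists, so its carry-over to the other place rests on a single step.

For compound 4 in this assay a step of a number 8 percentage points higher from compound 3 to compound 4 (within the scatter) is expected, somewhat smaller than the measured one, because a number 14 percentage points higher from compound 1 to compound 2 (beyond the scatter) sits close to the scatter and the place differs. The expected value for compound 4 is 22%, with a range from 5% to 40%.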

Compound 4, a percentage reported as inhibition, in the whole organism at one dose (the size of the read-out at that dose, not a potency): 8%
The estimate for compound 4 lay 14 percentage points above the measured number, and the stated range covers the measured number.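

In this assay, chloro in place of methyl on an aromatic carbon gives a number 6 percentage points lower from compound 3 to compound 4 (within the scatter), so the gain seen with this change at the place para to a group of 9 heavy atoms does not reappear at the place meta to a group of 9 heavy atoms, and compound 4 cannot be read as differing from compound 3. The two instances of the change therefore disagree, and this change cannot be carried from one core to the other in this series as a fixed step: the same change on two cores in this assay, a number 14 percentage points higher (beyond the scatter) from compound 1 to compound 2 and a number 6 percentage points lower (within the scatter) from compound 3 to compound 4, 20 percentage points apart, beyond the scatter of two such steps. This does not show why the instances differ, nor that chloro lowers the read-out on the core of compound 3, and with a single step on each core it gives no general rule for either place.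

The compounds shown carry only methyl and chloro on the aryl ring, so what an amine, a carboxylic acid or a longer chain would do at either place remains open. Also open, as far as these compounds go, is whether the disagreement between the two steps would hold at any dose other than the one given.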